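Propyl to ethyl on the shared core

The source may report more compounds than this note shows. Statements on the series, on what has been measured and on what is new or still open speak of the compounds shown alone.

Of the compounds shown here, three carry the same core and have been measured in an assay on HEK293 cells for inhibition of N-acylethanolamine-hydrolyzing acid amidase (Homo sapiens), read by fluorescence, with stated times of 10 min and 50 min; a lower number here means a stronger inhibitor, a higher number a weaker inhibitor. Compound 1 `CCCc1ccc(COC(=O)N[C@H]2CNC2=O)cc1` gives 52 nM in this assay. Compound 2 `O=C(N[C@H]1CNC1=O)OCc1ccc2c(c1)CCCC2` gives 140 nM in this assay, and compound 3 `O=C(N[C@H]1CNC1=O)OCCCC1CCCCC1` gives 44 nM in this assay. Among these three numbers compound 1 stands second highest; its nearest neighbour is compound 3, whose number is lower but within the scatter, so no order between compound 1 and compound 3 can be read. Compound 2 is furthest from compound 1, with a number higher by more than the scatter, so compound 2 is the weaker inhibitor of that pair. For the measured compounds named here, no two measured compounds differ in one place only, so no single step has been measured.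

Compound 4 `CCc1ccc(COC(=O)N[C@H]2CNC2=O)cc1` is not yet measured. Its difference from compound 1 is hydrogen in place of methyl on a saturated chain carbon, two bonds along the chain from an aromatic carbon, which reads as propyl to ethyl. Going by the values given here, nothing measured bears on this change directly; the three values give only the band in which the series so far sits. A modest weakening is expected, a 1.9-fold higher number from compound 1 to compound 4 (0.28 log units; within the scatter), at the edge of the scatter rather than clearly beyond it. Compound 4 is therefore estimated at 100 nM in this assay, with a range of 40 nM to 250 nM.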

Compound 4, half-maximal inhibitory concentration: 160 nM
Compound 4: middle estimate off by 1.6-fold (0.20 log units), on the low side; the range from low to high includes it.
By their numbers in this assay, from the lowest: compounds 3 and 1 (each within the scatter of the next); then compounds 2 and 4 (each within the scatter of the next).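

For the compounds shown here, the propyl to ethyl change gives the first single step: in this assay, hydrogen in place of methyl on a saturated chain carbon, two bonds along the chain from an aromatic carbon, gives a 3.1-fold higher number from compound 1 to compound 4 (0.49 log units; beyond the scatter). This position is therefore not indifferent to the length of the chain: the loss of one carbon, with no ring, hydrogen-bond donor, hydrogen-bond acceptor or net charge leaving or entering, moves the number beyond the scatter, towards a weaker inhibitor. The data shown offer no explanation for the size of this step.

On these data alone, only the shortening of the chain is covered here, so it remains open whether a butyl group or a longer chain at this place would hold the number of compound 1, improve on it or lose ground. Also open, as far as these compounds go, are a methyl group in place of the ethyl and a branched isopropyl group, as well as a propyl-length chain ending in an amine or a hydroxyl group, which would show whether carbon count alone governs the step.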